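Lengthening the Phenyl-Bearing Chain in a Leukotriene Antagonist Series

The source may hold more compounds than are shown below. What is called first, only, known or untested is meant among the compounds shown, and "the series" means these compounds.

Of the compounds shown here, two built on the same core have been tested in an assay on membranes from lung for binding affinity to cysteinyl leukotriene receptor 1 (Cavia porcellus); on this read-out higher numbers stand for weaker inhibition and lower numbers for stronger inhibition. Compound 1 `O=C(O)CCC[C@H](O)[C@@H](/C=C/CCCc1ccccc1)Sc1ccc(C(=O)O)cc1` carries a phenyl at the end of a short saturated chain. In this assay compound 1 returns only a limit, < 100000 nM, and not a number. Compound 2 `O=C(O)CCC[C@H](O)[C@@H](/C=C\CCCCCCCCCc1ccccc1)Sc1ccc(C(=O)O)cc1` carries a far longer chain ending in phenyl, and in this assay compound 2 gives 251 nM. That is the only number shown so far. The remaining value, for compound 1, is the limit of < 100000 nM in this assay, at which 1 of the 2 values shown sits. Compound 3 `O=C(O)CCC[C@H](O)[C@@H](/C=C\CCCCCCCCCCCc1ccccc1)Sc1ccc(C(=O)O)cc1`, not yet measured, differs from compound 2 in one place: phenethyl in place of phenyl on a saturated chain carbon, nine bonds along the chain from a double-bonded chain carbon. Among the measured compounds shown here, no step between two measured compounds is on hand, so the expected step from compound 2 to compound 3 rests on the change alone; it is estimated at a 1.1-fold higher number from compound 2 to compound 3 (0.05 log units; within the scatter), no larger than the usual scatter. Compound 3 is therefore expected to give about 280 nM, within a range from 80 nM to 1000 nM.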

Compound 3, inhibition constant: 1260 nM
For compound 3 the middle estimate is 4.5-fold (0.65 log units) below the measured one; measured number above the stated range.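

In this assay, phenethyl in place of phenyl, on a saturated chain carbon nine bonds along the chain from a double-bonded chain carbon, gives a 5.0-fold higher number from compound 2 to compound 3 (0.70 log units; beyond the scatter). Among the compounds shown here, this is the first readable step, and it shows that inhibition at this receptor is weaker with the longer chain end, so this position does respond to added length, at least for this one pair. Compound 1 adds no second step, since what it gives is a limit and not a number: the limit of < 100000 nM in this assay, at which 1 of the 3 values shown sits.

As far as these compounds go, whether a still longer chain weakens inhibition further, or a shorter one ending in benzyl strengthens it, stays open. Also open, from the compounds shown here alone, is whether the chain needs a phenyl ring at its end at all, or could instead end in a carboxylic acid or an amine.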